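The source may report more compounds than this note shows. Statements on the series, on what has been measured and on what is new or still open speak of the compounds shown alone.

In an assay on isolated protein for inhibition of glucose-6-phosphatase catalytic subunit 1 (Homo sapiens), read by inositol phosphate accumulation, with a stated time of 30 min, tested at 100 uM (a lower number here means less inhibition, a higher number more inhibition at the concentration tested (going by the name of the read-out)), compound 1 `CC1(C)CC(=O)C2=C(C1)NC(c1ccccc1)=CC2c1ccco1` gives 11.4%, and compound 2 `CC1(C)CC(=O)C2=C(C1)NC(C(=O)O)=CC2c1ccccc1` gives 17.1% in this assay; the two numbers lie within the scatter of each other, so neither stands apart. Compound 3 `COc1ccc(C2C=C(c3ccccc3)NC3=C2C(=O)CC(C)(C)C3)cc1` differs from compound 1 by 4-methoxyphenyl in place of furan-2-yl on a saturated ring carbon. For the measured compounds named here, no step between measured compounds speaks to this change. Compound 3 is expected to sit close to compound 1, with a step of a number 3.6 percentage points higher from compound 1 to compound 3 (within the scatter) that is not expected to exceed the scatter. For compound 3 the estimate in this assay is 15%, in the range from 3% to 35%.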

Compound 3, a percentage reported as inhibition, at one concentration (the size of the read-out at that concentration, not a potency): "not active" (no number reported)
No number was reported for compound 3, so the estimate cannot be set against anything.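

In this assay, for the compounds shown here, compound 3 was reported as not active without a number, so no step from compound 1 can be read, and no evidence bears on this result. As far as these compounds go, how far 4-methoxyphenyl in place of furan-2-yl shifts inhibition stays open.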